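A Ring Swap on an Aortic Relaxant Core

The source may report more compounds than this note shows. Statements on the series, on what has been measured and on what is new or still open speak of the compounds shown alone.

Of the compounds shown here, three sharing one core have been measured in a functional assay (aorta) with Rattus norvegicus as the target; on this read-out higher numbers stand for weaker inhibition and lower numbers for stronger inhibition. Compound 1 `CCC(C)(C)/N=C(\NC#N)N[C@@H]1c2cc(C#N)ccc2OC(C)(C)[C@H]1O` gives 29800 nM. Compound 2 `CC1(C)Oc2ccc(C#N)cc2[C@@H](NC(=O)Nc2cccnc2)[C@@H]1O` gives 500 nM. Compound 3 `CC1(C)Oc2ccc(C#N)cc2[C@@H](/N=C(\NC#N)Nc2cccc([N+](=O)[O-])c2)[C@@H]1O` gives 670 nM, a number that lies far below that of compound 1 and close to that of compound 2, within the usual scatter of such measurements. Among the compounds with values here, no pairs differing in a single place have been measured side by side, so no measured step is available as a guide.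

Compound 4 `CSc1ccc(N/C(=N/[C@@H]2c3cc(C#N)ccc3OC(C)(C)[C@H]2O)NC#N)cc1` has not yet been measured in this assay. It differs from compound 3 in one place: 4-(methylsulfanyl)phenyl in place of 3-nitrophenyl on an amine nitrogen. The group that leaves and the group that enters each carry one six-membered aromatic ring of carbon only, so the change is confined to what sits on that ring. Without a measured step of this kind to lean on, only a small move is expected, likely no further than the scatter allows. Compound 4 is estimated to give 900 nM in this assay, with a plausible range from 250 nM to 3500 nM, a step expected as a 1.3-fold higher number from compound 3 to compound 4 (0.13 log units; within the scatter).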

Compound 4, half-maximal inhibitory concentration: 6300 nM
Compound 4: middle estimate off by 7.0-fold (0.85 log units), on the low side; the measured number lies above the stated range.
By their numbers in this assay, from the lowest: compounds 2 and 3 (each within the scatter of the next); then compound 4; then compound 1.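

Within the data shown here, with 4-(methylsulfanyl)phenyl in place of 3-nitrophenyl on an amine nitrogen, this assay shows a 9.4-fold higher number from compound 3 to compound 4 (0.97 log units; beyond the scatter) and this is the first measured step at this position. The ring stays and only what it carries changes, yet the move is larger than the usual scatter, so this position does respond to what sits on that ring. No measured information on hand accounts for the size of this step.

The names of the two groups show that both the substituent and its place on the ring differ, so the compounds shown leave open which of these matters more. As far as these compounds go, it also remains open whether an unsubstituted phenyl, or a ring carrying a chlorine atom or a methoxy group, would lie closer to compound 3 or to compound 4.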